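The compounds below may be only part of what the source reports. "The series", "measured", "known", "first", "only" and "open" are said of these compounds alone.

Working notes on the series. The shared core is a benzamide bearing an aminophenyl group, carrying a dithiocarbamate-linked amine on the other side. In a functional assay on HeLa cells (Homo sapiens) for antiproliferative activity, read by CCK-8 assay, with a stated time of 72 h, tested at 2 uM (a higher number here means a stronger effect of the compound at the concentration tested, a lower number a weaker effect), compound 1 `Nc1ccccc1NC(=O)c1ccc(CSC(=S)N2CCN(c3ccccc3)CC2)cc1` gives 62.2%. Compound 2 `CCN(Cc1ccncc1)C(=S)SCc1ccc(C(=O)Nc2ccccc2N)cc1` gives 63.5% in this assay, a number within the scatter of that for compound 1. Compound 3 `CN(Cc1cccnc1)C(=S)SCc1ccc(C(=O)Nc2ccccc2N)cc1` gives 16.4% in this assay, well apart from both. Going by the values given here, the only change that has been followed within this assay is a number 47.1 percentage points lower from compound 2 to compound 3 (beyond the scatter); that change alters the acyclic amine on the thiocarbonyl carbon and says nothing directly about a substituent on a ring amine nitrogen. Compound 4 `Nc1ccccc1NC(=O)c1ccc(CSC(=S)N2CCN(Cc3ccccc3)CC2)cc1` differs from compound 1 by benzyl in place of phenyl on an amine nitrogen in a ring. Among the compounds with values here, no measured pair bears on that change, so nothing in the available numbers points to a direction for it; the one large step seen, from compound 2 to compound 3, shows only that the amine portion can matter. Compound 4 is therefore expected to lie close to compound 1 in this assay, at an estimated 58% with a range of 35% to 75%. The expected step of a number 4.2 percentage points lower from compound 1 to compound 4 (within the scatter) is estimated to be within the scatter.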

Compound 4, a percentage reported as inhibition, at one concentration (the size of the read-out at that concentration, not a potency): 20.6%
Compound 4: the middle estimate sits 37.4 percentage points above what was measured, and the stated range ends above it.
By their numbers in this assay, from the lowest: compounds 3 and 4 (each within the scatter of the next); then compounds 1 and 2 (each within the scatter of the next).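

In this assay, benzyl in place of phenyl on the amine nitrogen in the ring gives a number 41.6 percentage points lower from compound 1 to compound 4 (beyond the scatter), the first step followed at this position, and it shows that the group on this nitrogen can strongly change the read-out. The two groups both carry one six-membered aromatic ring of carbon only and have 0 hydrogen-bond donors and 0 hydrogen-bond acceptors. Benzyl has 7 heavy atoms against 6 in phenyl, and these other counts are the same in both groups. No measurement available here explains the step.

This single pair leaves open whether the difference follows the length of the link between the ring nitrogen and the aromatic ring, as a phenethyl group on the same nitrogen would help to test, or applies only to benzyl. It also leaves open how a non-aromatic group on that nitrogen, such as cyclohexyl or acetyl, would compare with phenyl and benzyl, and whether the step would hold at other concentrations.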